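A few compounds are considered here, and "the series" means these few. Any claim that something is new, unique, unknown or untested is made for them only; others in the source may bear on it.

Working notes on the series. Compound 1 `CC(C)(C)c1ccc(C(=O)/C=C/c2ccncc2)cc1` gives 47000 nM in a functional assay with Rattus norvegicus as the target; on this read-out lower numbers stand for stronger inhibition and higher numbers for weaker inhibition. Compound 2 `O=C(/C=C/c1ccncc1)c1ccc(Cl)cc1` gives 60000 nM, and the step of a 1.3-fold higher number from compound 1 to compound 2 (0.11 log units; within the scatter) lies within the scatter. Compound 3 `CN(C)c1ccc(C(=O)/C=C/c2ccncc2)cc1` gives 11000 nM, the lowest of the three numbers; the steps of a 4.3-fold lower number from compound 1 to compound 3 (0.63 log units; beyond the scatter) and a 5.5-fold lower number from compound 2 to compound 3 (0.74 log units; beyond the scatter) both lie beyond the scatter, so compound 3 is set apart from the other two, which sit together.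

Compound 4 `CSc1ccc(C(=O)/C=C/c2ccncc2)cc1` is the next member. It differs from compound 3 only at the group on the aromatic carbon of the six-membered aromatic ring of carbon only: methylsulfanyl in place of dimethylamino on an aromatic carbon. Within the data shown here, no measured step involves methylsulfanyl, so the bearing comes only from the two steps into compound 3: both show that dimethylamino is the one group among the three that gives a lower number, and tert-butyl and chloro give numbers alike within the scatter. Removing dimethylamino is therefore expected to move the number back up toward compounds 1 and 2, a step of about a 3.2-fold higher number from compound 3 to compound 4 (0.50 log units; beyond the scatter). Compound 4 is estimated at 35000 nM in this assay, with a range from 12000 nM to 90000 nM, pending measurement.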

Compound 4, half-maximal inhibitory concentration: 33000 nM
For compound 4 the middle estimate is 1.1-fold (0.03 log units) above the measured one, within the range that was stated.
By their numbers in this assay, from the lowest: compound 3; then compounds 4, 1 and 2 (each within the scatter of the next).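

In this assay the change to methylsulfanyl on this aromatic carbon gives a 3.0-fold higher number from compound 3 to compound 4 (0.48 log units; beyond the scatter) and so does not keep the lower number seen with dimethylamino. Set against chloro and tert-butyl, the steps are a 1.8-fold lower number from compound 2 to compound 4 (0.26 log units; within the scatter) and a 1.4-fold lower number from compound 1 to compound 4 (0.15 log units; within the scatter) and these three groups sit together, which leaves compound 3 alone apart from the rest among four groups at this position. No measured evidence bears on the reason for this separation.

Going by these compounds, whether the lower number is particular to dimethylamino or extends to other nitrogen groups stays open, and a primary amine, diethylamino or a pyrrolidine ring at this place would test that. Also open, on these data alone, is whether methoxy, the oxygen counterpart of methylsulfanyl, would sit with compound 4 or with compound 3.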